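The source may hold more compounds than are shown below. What is called first, only, known or untested is meant among the compounds shown, and "the series" means these compounds.

In a functional assay on HCT-116 cells (Homo sapiens) for antiproliferative activity, read by MTT assay, with a stated time of 24 h (on this read-out lower numbers stand for stronger inhibition and higher numbers for weaker inhibition), compound 1 `COc1cc(OC)c(-c2coc3cc(OCc4ccc(Br)cc4)ccc3c2=O)cc1OC` gives 1980 nM. Compound 2 `COc1cc(OC)c(-c2coc3cc(OCc4ccccc4C#N)ccc3c2=O)cc1OC` gives > 10000 nM, which is a limit and not a number. For the measured compounds named here, the series so far therefore holds (the limit of > 10000 nM in this assay, at which 1 of the 2 values shown sits). Going by the values given here, the only measured step, an at least 5.0-fold higher number from compound 1 to compound 2 (0.70 log units; beyond the scatter), lies beyond the scatter and replaces 4-bromophenyl with 2-cyanophenyl on a saturated chain carbon bound to an oxygen on an aromatic ring.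

Compound 3 `COc1cc(OC)c(-c2coc3cc(OCc4ccc(Cl)cc4)ccc3c2=O)cc1OC` has yet to be measured in this assay. It changes the same place: 4-chlorophenyl in place of 2-cyanophenyl on a saturated chain carbon bound to an oxygen on an aromatic ring. Here 4-chlorophenyl enters in place of 2-cyanophenyl, so the change moves away from the group that came with the loss of a measurable value. The entering group reads much like the 4-bromophenyl of compound 1, which gave 1980 nM, so a return towards that value is expected, though one measured step is thin support. A step beyond the scatter towards a lower number is expected in this assay. The estimated step is an at least 4.5-fold lower number from compound 2 to compound 3 (0.65 log units; beyond the scatter). Compound 3 is estimated at 2200 nM, with an expected range of 800 nM to 6000 nM.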

Compound 3, half-maximal inhibitory concentration: 4450 nM
The estimate for compound 3 lay 2.0-fold (0.31 log units) below the measured number; measured number inside the range.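

In this assay, 4-chlorophenyl on the saturated chain carbon bound to an oxygen on an aromatic ring brings back a measurable value, with an at least 2.2-fold lower number from compound 2 to compound 3 (0.35 log units; beyond the scatter). This place also responds to the halogen itself and not only to the presence of one: chloro in place of bromo on an aromatic carbon gives a 2.2-fold higher number from compound 1 to compound 3 (0.35 log units; beyond the scatter), so the two halogen-bearing compounds can be told apart, with the bromo compound 1 the stronger of the pair. Compound 2 remains a limit and not a number, so the step into compound 3 fixes only a minimum size and the true gap stays unknown: the limit of > 10000 nM in this assay, at which 1 of the 3 values shown sits.

Still open, from the compounds shown here alone, is whether the loss seen with 2-cyanophenyl belongs to the nitrile or to where it stands, as that group and 4-chlorophenyl differ in both substituent and ring place; a 4-cyanophenyl and a 2-chlorophenyl group would separate the two. Also open, going by these compounds, is where a 4-fluorophenyl or a 4-iodophenyl group would fall relative to compound 1 and compound 3, and so whether the order of the two halogens extends into a trend.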